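Trimming the Outer Ring: From Compound 2 to Compound 4

A few compounds are considered here, and "the series" means these few. Any claim that something is new, unique, unknown or untested is made for them only; others in the source may bear on it.

Of the compounds shown here, three sharing one core have been measured in an assay on cells for inhibition of Voltage-dependent T-type calcium channel subunit alpha-1G (Homo sapiens), read by patch clamp; a lower number here means a stronger inhibitor, a higher number a weaker inhibitor. Compound 1 `CN(C)CCCCCSC1=Nc2ccccc2C(CC(=O)NCc2ccccc2)N1c1ccc(-c2ccc(F)cc2)cc1` gives 250 nM. Compound 3 `CN(C)CCCCCSC1=Nc2ccccc2C(CC(=O)NCc2ccc(F)cc2)N1c1ccc(-c2ccc(F)cc2)cc1` gives 400 nM, and the change from compound 1 to compound 3, fluoro in place of hydrogen on an aromatic carbon, is a 1.6-fold higher number from compound 1 to compound 3 (0.20 log units; within the scatter). Compound 2 `O=C(CC1c2ccccc2N=C(SCCCCCN2CCCC2)N1c1ccc(-c2ccc(F)cc2)cc1)NCc1ccccc1` gives 2180 nM, the highest of the three numbers; the change from compound 1 to compound 2 is an 8.7-fold higher number from compound 1 to compound 2 (0.94 log units; beyond the scatter), so compound 2 is the weakest inhibitor among those measured.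

Compound 4 `O=C(CC1c2ccccc2N=C(SCCCCCN2CCCC2)N1c1ccccc1)NCc1ccccc1` differs from compound 2 in one place: hydrogen in place of 4-fluorophenyl on an aromatic carbon. Neither measured step touches this part of the molecule; both concern the amine at the end of the chain or the benzyl amide, so nothing in the data speaks directly to the size or direction of this change. The removed group is the largest single piece so far varied, and a change of this size is expected to move the number by more than the scatter, most plausibly toward weaker inhibition. For compound 4 the expected value in this assay is 5000 nM, with a range of 1500 nM to 16000 nM, which is an expected step of a 2.3-fold higher number from compound 2 to compound 4 (0.36 log units; beyond the scatter).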

Compound 4, half-maximal inhibitory concentration: 77000 nM
Beside the measured number, compound 4's estimate is 15-fold (1.19 log units) below it; the whole stated range lies below it.
By their numbers in this assay, from the lowest: compounds 1 and 3 (each within the scatter of the next); then compound 2; then compound 4.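

In this assay, the loss of the 4-fluorophenyl group, with only a hydrogen left on that aromatic carbon, gives a 35-fold higher number from compound 2 to compound 4 (1.55 log units; beyond the scatter) and is a large step beyond the scatter. Going by these compounds alone, the earlier steps changed only the amine at the end of the chain or the benzyl amide, so this is the first reading at this position, and it shows that inhibition in this pair depends strongly on the 7 heavy atoms of the 4-fluorophenyl group, with compound 4 the weakest inhibitor of the four. Nothing measured here explains why this group matters so much.

The compounds shown leave open whether the step comes from the outer ring itself or from its fluorine, a question that a plain phenyl group at this place could help settle, while a smaller group such as chloro or methyl would show how much of the ring is needed. They also leave open whether the loss would be as large with dimethylamino at the end of the chain, since this step is read only with pyrrolidin-1-yl there.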